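Chloro step from compound 1 to compound 3

This account rests on a few compounds, and the source may have more. Where it says the series, first, only, none or still open, it means among the compounds named here.

In a functional assay on MCF7 cells (Homo sapiens) for antiproliferative activity, read by MTT assay, with a stated time of 48 h (a lower number here means a stronger inhibitor, a higher number a weaker inhibitor), compound 1 (`N=C(N)N/N=C(/C=C/c1ccccc1)c1ccccc1`) gives 17000 nM. In the same test compound 2 (`COc1cccc(/C=C/C(=N/NC(=N)N)c2ccccc2)c1`) gives 13000 nM. For the measured compounds named here, these are the only two numbers so far, and they lie within the scatter of each other, so compound 1 has no clear rank.

The next compound is compound 3 (`N=C(N)N/N=C(/C=C/c1ccccc1)c1ccc(Cl)cc1`), which differs from compound 1 by one change: chloro in place of hydrogen on an aromatic carbon. In words, this is chloro in place of hydrogen on an aromatic carbon, para to a large group, turning phenyl into 4-chlorophenyl.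

Going by the values given here, one measured step bears on this change, a 1.3-fold lower number from compound 1 to compound 2 (0.12 log units; within the scatter). It also replaces hydrogen on an aromatic carbon, but with methoxy, so it is only a loose guide. Among the compounds with values here, no chloro compound has been measured yet. No step beyond the scatter is therefore expected in this assay, with a slight lean towards a lower number. The expected step is a 1.4-fold lower number from compound 1 to compound 3 (0.15 log units; within the scatter).

For compound 3 the estimated value is 12000 nM, with an expected range of 5000 nM to 26000 nM.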

Compound 3, half-maximal inhibitory concentration: 350 nM
Compound 3: middle estimate off by 34-fold (1.54 log units), on the high side, and the stated range ends above it.
By their numbers in this assay, from the lowest: compound 3; then compounds 2 and 1 (each within the scatter of the next).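

In this assay, for the compounds shown here, the change from phenyl to 4-chlorophenyl is the first to go beyond the scatter, with a 49-fold lower number from compound 1 to compound 3 (1.69 log units; beyond the scatter), whereas the methoxy change gave only a 1.3-fold lower number from compound 1 to compound 2 (0.12 log units; within the scatter). Replacing hydrogen on an aromatic carbon of the core of compound 1 is therefore not a silent edit in every case, and the aromatic carbon para to a large group now stands as a place where a single chlorine atom goes with a large drop in the number. Nothing in hand explains the size of this step, and with one chloro compound it rests on a single pair.

On these data alone, whether the step belongs to chloro itself or would also appear with fluoro, bromo, methyl or trifluoromethyl at the same place remains open. Also open, as far as these compounds go, is whether chloro on other aromatic carbons of the core gives a step of similar size, and whether chloro and methoxy together in one compound would behave as the two separate steps do.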